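The compounds below may be only part of what the source reports. "The series", "measured", "known", "first", "only" and "open" are said of these compounds alone.

Compound 1 `N#C/C(=C\c1ccccc1OS(=O)(=O)c1ccc(Cl)cc1)C(=O)Nc1nnc(Cc2ccccc2)s1` is the starting point of this small series. In a functional assay on HL-60 cells (Homo sapiens) for inhibition, read by CCK-8 assay, with a stated time of 48 h, tested at 20 uM (on this read-out lower numbers stand for less inhibition of growth and higher numbers for more inhibition of growth at the one concentration tested), compound 1 gives 26%. Compound 2 `N#C/C(=C\c1ccccc1OS(=O)(=O)c1ccc(F)cc1)C(=O)Nc1nnc(Cc2ccccc2)s1` carries the change (fluoro in place of chloro on an aromatic carbon), and in this assay compound 2 gives 22%; the step of a number 4 percentage points lower from compound 1 to compound 2 (within the scatter) is small. Compound 3 `N#C/C(=C\c1ccccc1OS(=O)(=O)c1ccc(Cl)cc1)C(=O)Nc1nnc(Cc2ccc(Cl)cc2)s1` differs from compound 1 by chloro in place of hydrogen on an aromatic carbon, and in this assay compound 3 gives 15%, the step being a number 11 percentage points lower from compound 1 to compound 3 (beyond the scatter).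

Compound 4 `N#C/C(=C\c1ccccc1OS(=O)(=O)c1ccc(F)cc1)C(=O)Nc1nnc(Cc2ccc(Cl)cc2)s1` has not yet been measured. It differs from compound 3 by fluoro in place of chloro on an aromatic carbon, which is the same change as that made from compound 1 to compound 2, now on the core of compound 3; the cores differ by chloro in place of hydrogen on an aromatic carbon. The step from compound 3 to compound 4 is therefore expected to be small, because a number 4 percentage points lower from compound 1 to compound 2 (within the scatter) was itself within the scatter. On that basis the expected step is a number 3 percentage points lower from compound 3 to compound 4 (within the scatter). Compound 4 is estimated to give 12% in this assay, likely between 3% and 22%.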

Compound 4, percent growth inhibition at one concentration: 20%
Beside the measured number, compound 4's estimate is 8 percentage points below it, and the stated range covers the measured number.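

In this assay, the swap of 4-chlorophenyl for 4-fluorophenyl on the sulfonyl group gives a new step, a number 5 percentage points higher from compound 3 to compound 4 (within the scatter), and this stands close to the earlier step on the core of compound 1: the same change on two cores in this assay, a number 4 percentage points lower (within the scatter) from compound 1 to compound 2 and a number 5 percentage points higher (within the scatter) from compound 3 to compound 4, 9 percentage points apart, within the scatter of two such steps. Chloro in place of hydrogen on the other aromatic ring gives a number 2 percentage points lower from compound 2 to compound 4 (within the scatter), so the step beyond the scatter seen on the core of compound 1 does not recur here, yet the two steps cannot be called different: the same change on two cores in this assay, a number 11 percentage points lower (beyond the scatter) from compound 1 to compound 3 and a number 2 percentage points lower (within the scatter) from compound 2 to compound 4, 9 percentage points apart, within the scatter of two such steps. These four compounds therefore show no sign that either change behaves differently on the two cores, but with steps this small and one concentration tested, they do not show that the changes carry over unaltered either.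

Open, on these data alone, is whether a methoxy, a nitro or an amine in place of the halogen on either aromatic ring would move the number beyond the scatter. Also open, as far as these compounds go, is what a carboxylic acid or a longer chain on the shared core would do.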